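The source may report more compounds than this note shows. Statements on the series, on what has been measured and on what is new or still open speak of the compounds shown alone.

Measured in a functional assay on HepG2 cells (Homo sapiens) for antiproliferative activity, read by sulforhodamine B assay, with a stated time of 48 h; on this read-out higher numbers stand for weaker inhibition and lower numbers for stronger inhibition:
- Compound 1 `COc1cc(/C=C/C(=O)c2ccccc2-c2ccc(F)cc2)ccc1O`: 2800 nM
- Compound 2 `COc1ccc(C(=O)/C=C/c2ccccc2-c2ccc(F)cc2)cc1`: 6300 nM

Of these two, compound 2 has the higher number and so the weaker inhibition, and the gap to compound 1 lies beyond the usual scatter. Compound 3 `COc1ccc(C(=O)/C=C/c2ccccc2-c2ccc(F)nc2)cc1` has 6-fluoropyridin-3-yl in place of 4-fluorophenyl on an aromatic carbon, ortho to a large group: 6-fluoropyridin-3-yl in place of 4-fluorophenyl on an aromatic carbon. Among the measured compounds shown here, no measured pair shows what this swap does in this assay, so the expectation is uncertain. No change beyond the scatter is expected, with a slight lean towards weaker inhibition. The estimated step is a 1.3-fold higher number from compound 2 to compound 3 (0.10 log units; within the scatter). The estimate for compound 3 is 8000 nM, with an expected range of 3000 nM to 20000 nM.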

Compound 3, half-maximal inhibitory concentration: 8200 nM
For compound 3 the middle estimate is 1.0-fold (0.01 log units) below the measured one; low and high end bracket the measured number.
By their numbers in this assay, from the lowest: compound 1; then compounds 2 and 3 (each within the scatter of the next).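

In this assay, placing 6-fluoropyridin-3-yl where compound 2 has 4-fluorophenyl gives a 1.3-fold higher number from compound 2 to compound 3 (0.11 log units; within the scatter). So on this aromatic carbon, ortho to a large group, a ring nitrogen and the hydrogen-bond acceptor it adds can enter without a change beyond the scatter. No supporting data are available to explain this result. On these data alone, it remains open how this position would respond to a different kind of group, such as an amine or a carboxylic acid, in place of the fluorinated ring. As far as these compounds go, the same swap on compound 1 is also open.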